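The compounds below may be only part of what the source reports. "The series", "measured", "known", "first", "only" and "open" are said of these compounds alone.

Among the compounds with values here, in a functional assay on CPT30 cells for inhibition, with CPT30 cell line (Homo sapiens) as the target, read by MTT assay (on this read-out lower numbers stand for stronger inhibition and higher numbers for weaker inhibition), compound 1 `COc1ccc(N)c(C(=O)c2cc(OC)c(OC)c(OC)c2)c1` gives 41 nM and compound 2 `COc1cc(C(=O)c2cc(Cl)ccc2N)cc(OC)c1OC` gives 60.3 nM in the same read-out, which places compound 2 within the scatter of the only other measured compound. Within the data shown here, the single measured step, a 1.5-fold higher number from compound 1 to compound 2 (0.17 log units; within the scatter) and with chloro in place of methoxy on an aromatic carbon, lies at a different place from the change now in question. Compound 3 `CNc1ccc(Cl)cc1C(=O)c1cc(OC)c(OC)c(OC)c1` differs from compound 2 by methyl in place of hydrogen on a nitrogen on an aromatic ring in an amino to methylamino change. Among the measured compounds shown here, no measured step tests that nitrogen, so the data offer no direct size, and the expectation is only a modest move toward a higher number, held loosely. The expected change is a 2.5-fold higher number from compound 2 to compound 3 (0.40 log units; beyond the scatter) and no more than a rough guide. For compound 3 the estimated value is 150 nM within an expected range of 40 nM to 700 nM in this read-out.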

Compound 3, half-maximal inhibitory concentration: 5350 nM
The estimate for compound 3 lay 36-fold (1.55 log units) below the measured number, outside the stated range (above it).
By their numbers in this assay, from the lowest: compounds 1 and 2 (each within the scatter of the next); then compound 3.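

In this assay, the nitrogen on the aromatic ring proves much more sensitive than the aromatic carbon tested earlier: methyl in place of hydrogen gives a large loss of inhibition (an 89-fold higher number from compound 2 to compound 3 (1.95 log units; beyond the scatter)), while chloro in place of methoxy stayed within the scatter (a 1.5-fold higher number from compound 1 to compound 2 (0.17 log units; within the scatter)). The amino to methylamino change adds only one carbon, yet this single place carries a far larger step than the only other place tested. Nothing shown here explains the size of this step.

The compounds shown leave open whether a longer chain such as ethyl, or an acetyl group, on that nitrogen would behave as the methyl does. They also leave open whether the same change on the core of compound 1, which carries methoxy instead of chloro, would give a step of similar size.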